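The source may hold more compounds than are shown below. What is called first, only, known or untested is meant among the compounds shown, and "the series" means these compounds.

Compound 1 `Cc1ccc(C2(c3ccc(O)cc3)C(=O)Nc3c2ccc(F)c3F)cc1` — 0.8 nM
Compound 2 `COc1ccc(C2(c3ccc(O)cc3)C(=O)Nc3c2ccc(F)c3F)cc1` — 2 nM; 2.2 nM; > 1000 nM (3 entries)
Compound 3 `O=C1Nc2c(ccc(F)c2F)C1(c1ccncc1)c1ccc(O)cc1` — 110 nM

In a functional assay on PC-3 cells (Homo sapiens) for cytotoxicity, read by WST assay, with a stated time of 72 h (on this read-out higher numbers stand for weaker inhibition and lower numbers for stronger inhibition), compound 1 gives 0.8 nM, the lowest of the two single numbers available. Compound 3 stands nearest to it, and the step of a 140-fold higher number from compound 1 to compound 3 (2.14 log units; beyond the scatter) is large. Compound 2 has several entries, (the several entries of compound 2 in this assay, 2 nM; 2.2 nM; > 1000 nM (3 entries)). One of the entries for compound 2 is a limit of the assay rather than a number.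

Compound 4 `O=C1Nc2c(ccc(F)c2F)C1(c1ccc(O)cc1)C1CCCCCCC1` differs from compound 1 in one place: cyclooctyl in place of 4-methylphenyl on a saturated ring carbon. Going by the values given here, no measured step exchanges an aromatic ring for a saturated one on this carbon, so the expectation rests on indirect ground. Among the compounds with values here, the only measured step at this position, from compound 1 to compound 3, shows that the group on this carbon can move the number a great deal. A number higher than that of compound 1 is therefore expected, with wide uncertainty. For compound 4 the estimate is 20 nM, most likely between 2 nM and 300 nM. The expected step is a 25-fold higher number from compound 1 to compound 4 (1.40 log units; beyond the scatter).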

Compound 4, half-maximal inhibitory concentration: > 1000 nM
Compound 4 gave a limit, no number; the forecaster's own chance of this, stated with the estimate: 15%; middle value at least 50-fold (1.69 log units) away from the limit.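

The step to cyclooctyl on this saturated ring carbon is an at least 1200-fold higher number from compound 1 to compound 4 (3.09 log units; beyond the scatter), which shows that this position can lose far more activity than compound 3 alone suggested. Set against the pyridin-4-yl group, the same exchange gives an at least 9.0-fold higher number from compound 3 to compound 4 (0.95 log units; beyond the scatter), so the two aromatic rings in compound 1 and compound 3, despite their large gap, both stay ahead of this non-aromatic ring. Both steps rest on a limit of the assay and give only a smallest size, and the same limit also occurs for another compound, which calls for care in reading it: the several entries of compound 2 in this assay, 2 nM; 2.2 nM; > 1000 nM (3 entries)

Going by these compounds, how far beyond the limit compound 4 lies stays open, as does whether the loss follows any saturated ring or this eight-membered ring in particular. A cyclopropyl or cyclohexyl ring, or an open butyl chain, on the same carbon would help to separate those two readings.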